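Acetyl to Amino Acid Carbonyl: Estimating Growth Inhibition

The source may report more compounds than this note shows. Statements on the series, on what has been measured and on what is new or still open speak of the compounds shown alone.

Compound 1 `CC(C)(CO)COC1(c2ccc(Cl)cc2)c2ccccc2C(=O)N1Cc1ccccc1`: 71000 nM
Compound 2 `CC(=O)OCC(C)(C)COC1(c2ccc(Cl)cc2)c2ccccc2C(=O)N1Cc1ccc(Cl)cc1`: 35000 nM

Both measurements come from a functional assay on HCT-116 cells (Homo sapiens) for inhibition, read by fluorescence, with a stated time of 48 h; on this read-out lower numbers stand for stronger inhibition of growth and higher numbers for weaker inhibition of growth. Compound 1 gives 71000 nM and compound 2 gives 35000 nM, so compound 2 stands with the lower of the two numbers, and the gap between the two lies beyond the usual scatter. The two compounds differ in more than one place, so no single change has yet been tied to a measured step.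

Compound 3 `CC(C)[C@H](N)C(=O)OCC(C)(C)COC1(c2ccc(Cl)cc2)c2ccccc2C(=O)N1Cc1ccc(Cl)cc1` has not yet been measured in this assay. It differs from compound 2 in one place: 1-amino-2-methylpropyl in place of methyl on a carbonyl carbon. Cut one bond further out, the acetyl becomes a (1-amino-2-methylpropyl)carbonyl group, while the shared core is untouched.

Within the data shown here, with no measured step of this kind to lean on, the expected step of a 1.4-fold lower number from compound 2 to compound 3 (0.15 log units; within the scatter) is small, no larger than the scatter, and its direction cannot be called from these numbers. Compound 3 is therefore estimated at 25000 nM, within a range of 8000 nM to 80000 nM.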

Compound 3, concentration for 50% growth inhibition: 11000 nM
Beside the measured number, compound 3's estimate is 2.3-fold (0.36 log units) above it; the measured number falls inside the stated range.
By their numbers in this assay, from the lowest: compound 3; then compound 2; then compound 1.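

Among these compounds, this is the first step that can be tied to a single change. In this assay, putting 1-amino-2-methylpropyl in place of methyl on a carbonyl carbon gives a 3.2-fold lower number from compound 2 to compound 3 (0.50 log units; beyond the scatter), a modest step that lies beyond the usual scatter, so growth inhibition responds to what sits at this position while the shared core stays the same. Nothing measured here explains why the number falls.

The new group differs from methyl in several ways at once, adding an amine, a branched carbon chain and a defined stereocentre, so the compounds shown leave open which of these carries the step; a 2-methylpropyl group without the amine and a 1-aminoethyl group with the shorter chain would help to separate them. Also open, as far as these compounds go, is how the mirror-image form of the stereocentre, or a carboxylic acid in place of the amine, would compare with compound 3 at 11000 nM.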